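The compounds below may be only part of what the source reports. "The series", "measured", "known", "first", "only" and "open" are said of these compounds alone.

Series notes, with all values from an ADME assay on liver (Mus musculus) for metabolic stability, read by LC-MS, using microsomes and NADPH; a lower number here means that less of the compound is left, a higher number that more of the compound is left. Compound 1 (`CCCN(Cc1ccc(OCCN2C(=O)CCC2=O)c(C)c1)[C@@H](CC(=O)O)c1ccc(Cl)cc1`) gives 97%, compound 2 (`Cc1cc(CN(CC2CC2)[C@@H](CC(=O)O)c2ccc(Cl)cc2)ccc1OCCN1C(=O)CCC1=O`) gives 87% and compound 3 (`Cc1cc(CN(CC2CCCC2)C(CC(=O)O)c2ccc(Cl)cc2)ccc1OCCN1C(=O)CCC1=O`) gives 52%. Compound 3 has the lowest of these numbers, and the values of compound 1 and compound 2 both stand above it by more than the scatter.

The next compound is compound 4 (`Cc1cc(CN(CC2CCCC2)[C@@H](CC(=O)O)c2ccc(Cl)cc2)ccc1OCCN1C(=O)CCC1=O`). the two compounds have the same atoms and bonds; at least one stereo element is drawn with a configuration in one of them and without one in the other: 1 of 1 stereo elements differ; a stereocentre at a saturated chain carbon is drawn without a configuration in compound 3 and S in compound 4 Thus a stereocentre at a saturated chain carbon is drawn without a configuration in compound 3 and S in compound 4.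

Going by the values given here, only one measured step is available, a number 10 percentage points lower from compound 1 to compound 2 (within the scatter). It lies within the scatter, but it concerns the chain on the amine nitrogen and not a stereo element, so it gives no direct size for the present change. Among the compounds with values here, no measured pair in this assay isolates a change in drawn configuration. Compound 1 and compound 2 do carry a drawn configuration at this carbon, but they also differ from compound 3 in that chain, so their values cannot be assigned to the configuration alone.

With the same atoms and bonds, no shift beyond the scatter is expected, and the uncertainty remains wide. The expected change is a number 4 percentage points higher from compound 3 to compound 4 (within the scatter). For compound 4 the estimated value is 56%, with an expected range of 38% to 76%.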

Compound 4, percent of the compound remaining: 69%
The estimate for compound 4 lay 13 percentage points below the measured number; low and high end bracket the measured number.
By their numbers in this assay, from the lowest: compound 3; then compound 4; then compounds 2 and 1 (each within the scatter of the next).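

In this assay, a change that leaves atoms and bonds untouched now gives a step beyond the scatter, a number 17 percentage points higher from compound 3 to compound 4 (beyond the scatter), and the only difference behind it is this: the fact that one of compounds 3 and 4 is drawn with a defined configuration and the other without, at the place where they differ With the S configuration drawn throughout, the chain on the amine nitrogen can also be compared without that difference, and cyclopentyl in place of cyclopropyl gives a number 18 percentage points lower from compound 2 to compound 4 (beyond the scatter), while cyclopentyl in place of ethyl gives a number 28 percentage points lower from compound 1 to compound 4 (beyond the scatter). Going by these compounds alone, the earlier step between the two smaller groups, a number 10 percentage points lower from compound 1 to compound 2 (within the scatter), stayed within the scatter, so cyclopentyl is the first group on this chain to separate from the others beyond it.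

The compounds shown do not tell what the undrawn centre of compound 3 holds, nor how the R configuration at this carbon would read with any of these chains. Nor do they show whether the fall continues smoothly with group size, since a cyclobutyl group, a cyclohexyl group or a longer chain such as butyl on the amine nitrogen would be needed to place cyclopentyl in a trend.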